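The compounds below may be only part of what the source reports. "The series", "measured", "known", "first", "only" and "open" are said of these compounds alone.

Measured compounds:
- compound 1, `CCCCCCCCCCc1ccc(-c2noc(CCCN(C)C)n2)cc1`, with 8% in an assay on HeLa cells for inhibition of sphingosine-1-phosphate transporter SPNS2 (Mus musculus), read by LC-MS, tested at 2 uM; a higher number here means more inhibition at the concentration tested (going by the name of the read-out), a lower number less inhibition
- compound 2, `CCCCCCCCCCc1ccc(-c2noc([C@@H]3CCCN3)n2)cc1`, with 21% in this assay
- compound 3, `CCCCCCCCCCc1ccc(-c2noc(CC(CN)OC(C)=O)n2)cc1`, with 0% in this assay

Compound 1 stands second highest of the three numbers. Its nearest neighbour is compound 3, which lies within the scatter of it, so the two cannot be ordered; compound 2 lies beyond the scatter above it, as the step of a number 13 percentage points higher from compound 1 to compound 2 (beyond the scatter) shows.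

The unmeasured compound 4 is `CCCCCCCCCCc1ccc(-c2noc([C@@H](N)CCCCN)n2)cc1`. It differs from compound 1 at one place: 1,5-diaminopentyl in place of 3-(dimethylamino)propyl on an aromatic carbon. The new group sits on an aromatic carbon of the shared core, next to the ring nitrogen and next to the ring oxygen.

Within the data shown here, two measured steps bear on this change. The step of a number 13 percentage points higher from compound 1 to compound 2 (beyond the scatter) replaced the same 3-(dimethylamino)propyl with another nitrogen-bearing group and gave a modest rise. The step of a number 8 percentage points lower from compound 1 to compound 3 (within the scatter), which brought in an oxygen-bearing group with a primary amine, stayed within the scatter, and the step of a number 21 percentage points lower from compound 2 to compound 3 (beyond the scatter) fell back modestly. Since compound 4 carries two free amines and no acetate, a modest rise like that to compound 2 is expected, a number 12 percentage points higher from compound 1 to compound 4 (beyond the scatter), though the small spread of the numbers keeps the range wide. Compound 4 is therefore estimated at 20%, between 5% and 40%.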

Compound 4, a percentage reported as inhibition, at one concentration (the size of the read-out at that concentration, not a potency): 43%
Compound 4: the middle estimate sits 23 percentage points below what was measured; measured number above the stated range.
By their numbers in this assay, from the lowest: compounds 3 and 1 (each within the scatter of the next); then compound 2; then compound 4.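

Among these compounds, at this place on the shared core, an aromatic carbon of the five-membered ring, 1,5-diaminopentyl is the first group to lift the number in this assay clear of all the others: replacing 3-(dimethylamino)propyl gives a number 35 percentage points higher from compound 1 to compound 4 (beyond the scatter), replacing the acetate-bearing chain gives a number 43 percentage points higher from compound 3 to compound 4 (beyond the scatter), and replacing pyrrolidin-2-yl gives a number 22 percentage points higher from compound 2 to compound 4 (beyond the scatter). The earlier compounds shown here showed only a modest rise at this position; compound 4 shows that a much higher number is reachable here, and that an open chain with no ring can reach it, so the ring of pyrrolidin-2-yl is not needed. Nothing measured here accounts for the size of this rise.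

The step changes several things at once, so the compounds shown do not separate the contribution of the amine on the carbon attached to the ring, the amine at the chain end, the chain length or the defined stereocentre. A version with a shorter or longer chain between the two amines, a guanidine at the chain end, or a carboxylic acid there instead would begin to pull these apart.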